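A few compounds are considered here, and "the series" means these few. Any claim that something is new, unique, unknown or untested is made for them only; others in the source may bear on it.

Working notes on the series. The compounds carry a nitro group and a trifluoromethyl group on a shared core; compound 1 `CN(Cc1ccc2c(c1)OCCO2)c1nc(=O)c2cc(C(F)(F)F)cc([N+](=O)[O-])c2o1` has one core, compound 2 `O=c1cc(NCc2ccccc2)sc2c([N+](=O)[O-])cc(C(F)(F)F)cc12` and the untested compound 4 `O=c1cc(NCc2ccc3c(c2)OCCO3)sc2c([N+](=O)[O-])cc(C(F)(F)F)cc12` share a second, and compound 3 `O=c1nc(NCc2cccc(F)c2)oc2c([N+](=O)[O-])cc(C(F)(F)F)cc12` a third. In an ADME assay on Vero cells (Chlorocebus sabaeus) for cytotoxicity, read by MTT assay, with a stated time of 48 h (on this read-out lower numbers stand for stronger inhibition and higher numbers for weaker inhibition), compound 1 gives 9.27 ug/mL. In this assay compound 2 gives only a limit, > 64 ug/mL, and not a number. Compound 3 likewise reaches only a limit of > 64 ug/mL in this assay. Going by the values given here, compound 2 thus stands at the limit of > 64 ug/mL in this assay, at which 2 of the 3 values shown sit, so no measured step can be drawn from it. Compound 4 differs from compound 2 by 2,3-dihydro-1,4-benzodioxin-6-yl in place of phenyl on a saturated chain carbon bound to a nitrogen on an aromatic ring. The step from compound 2 to compound 4 is expected to be small, estimated at an at least 1.4-fold lower number from compound 2 to compound 4 (0.15 log units; that floor lies within the scatter), with only compound 1 carrying the same entering group alongside a number. Compound 4 is expected to give about 45 ug/mL, within 15 ug/mL to 64 ug/mL.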

Compound 4, half-maximal inhibitory concentration: > 64 ug/mL
Compound 4: only a limit was reported; the forecaster's own chance of this, stated with the estimate: 55%; middle value at least 1.4-fold (0.15 log units) away from the limit.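

Compound 2 and compound 4 both give only a limit and not a number, so no step can be read between them. The compounds shown leave open what 2,3-dihydro-1,4-benzodioxin-6-yl in place of phenyl does to cytotoxicity on this core.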